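The source may report more compounds than this note shows. Statements on the series, on what has been measured and on what is new or still open speak of the compounds shown alone.

Three compounds share one core and differ only in the chain on the saturated carbon bound to the aromatic nitrogen. In an in vitro ADME assay on microsomes from liver (Homo sapiens) for metabolic stability (on this read-out lower numbers stand for a shorter-lived compound and higher numbers for a longer-lived compound), compound 2 `CC(C)(C)CCn1nc(-c2cccs2)c(O)c(C2=NS(=O)(=O)c3cc(OCC(N)=O)ccc3N2)c1=O` gives 0.35 h, compound 1 `CC(C)CCn1nc(-c2cccs2)c(O)c(C2=NS(=O)(=O)c3cc(OCC(N)=O)ccc3N2)c1=O` gives 0.383 h and compound 3 `CC(C)(F)CCn1nc(-c2cccs2)c(O)c(C2=NS(=O)(=O)c3cc(OCC(N)=O)ccc3N2)c1=O` gives 0.65 h; the steps of a 1.1-fold lower number from compound 1 to compound 2 (0.04 log units; within the scatter), a 1.7-fold higher number from compound 1 to compound 3 (0.23 log units; within the scatter) and a 1.9-fold higher number from compound 2 to compound 3 (0.27 log units; within the scatter) all fall within the scatter, so compound 2 stands among the others with no real separation. Compound 4 `NC(=O)COc1ccc2c(c1)S(=O)(=O)N=C(c1c(O)c(-c3cccs3)nn(CC3CCCCC3)c1=O)N2` carries cyclohexyl in place of neopentyl on a saturated chain carbon bound to an aromatic nitrogen. Among the compounds with values here, no measured step swaps a chain for a ring; the three known steps alter the same chain and none left the scatter, so for compound 4 in this assay a step of a 1.1-fold higher number from compound 2 to compound 4 (0.06 log units; within the scatter) is expected, not beyond the scatter, with an estimate of 0.4 h and a range from 0.2 h to 0.8 h.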

Compound 4, half-life: > 1 h
Compound 4: a limit, no number; the forecaster's own chance of this, stated with the estimate: 5%; at least 2.5-fold (0.39 log units) between middle value and limit.
By their numbers in this assay, from the lowest: compounds 2, 1 and 3 (each within the scatter of the next). At a limit, above all of these: compound 4.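

In this assay compound 4 gives a limit, not a number: the limit of > 1 h in this assay, at which 1 of the 4 values shown sits. Within the data shown here, changing the open chain to a ring, with cyclohexyl on the saturated chain carbon bound to an aromatic nitrogen, gives the only steps here that leave the scatter: an at least 2.8-fold higher number from compound 2 to compound 4 (0.45 log units; beyond the scatter) and an at least 2.6-fold higher number from compound 1 to compound 4 (0.41 log units; beyond the scatter). Going by these compounds, the third step, an at least 1.5-fold higher number from compound 3 to compound 4 (0.18 log units; that floor lies within the scatter), is only a floor, so the true size of that gap stays unknown. Still open, on these data alone, is how far compound 4 lies past its limit, and whether a cyclopentyl ring, or a cyclohexyl ring carrying an amine or a carboxylic acid, would give a similar step at this position.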